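The source may report more compounds than this note shows. Statements on the series, on what has been measured and on what is new or still open speak of the compounds shown alone.

Values so far in a functional assay on MKN-74 cells (Homo sapiens) for antiproliferative activity, with a stated time of 24 h (a higher number here means a weaker inhibitor, a lower number a stronger inhibitor), are these:
- compound 1 (`Cc1ccccc1NC(=S)N1CCc2c(sc(NC(=O)c3ccccc3Cl)c2C(N)=O)C1`) gives 11700 nM
- compound 2 (`NC(=O)c1c(NC(=O)c2ccccc2Cl)sc2c1CCN(C(=S)Nc1cccnc1)C2`) gives 38600 nM

For the measured compounds named here, compound 1 holds the lower of the two numbers, and compound 2 is its only neighbour on the scale. Compound 3 (`Cc1ccccc1NC(=S)N1CCc2c(sc(NC(=O)c3ccccc3C(F)(F)F)c2C(N)=O)C1`) keeps the rest of compound 1 and differs in one group (trifluoromethyl in place of chloro on an aromatic carbon): trifluoromethyl in place of chloro on an aromatic carbon, ortho to a large group. Going by the values given here, no measured step touches this group. Among the compounds with values here, the one available step (a 3.3-fold higher number from compound 1 to compound 2 (0.52 log units; beyond the scatter)) lies at another place on the molecule and gives only a rough measure of how far a single change moves the numbers. Going by that step, a change of no more than that modest size is expected in this assay with no direction favoured, and quite possibly none beyond the scatter. The estimate amounts to an expected step of a 1.1-fold higher number from compound 1 to compound 3 (0.05 log units; within the scatter) here. For compound 3 the expected value is 13000 nM with an estimated range from 5500 nM to 30000 nM in this read-out.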

Compound 3, half-maximal inhibitory concentration: 47400 nM
Compound 3: middle estimate off by 3.6-fold (0.56 log units), on the low side; measured number outside the range, above it.
By their numbers in this assay, from the lowest: compound 1; then compounds 2 and 3 (each within the scatter of the next).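

In this assay the change from 2-chlorophenyl to 2-(trifluoromethyl)phenyl gives a 4.1-fold higher number from compound 1 to compound 3 (0.61 log units; beyond the scatter) and so shows that this position, untouched by the earlier step, does affect the read-out. Of the two groups shown on this aromatic carbon, chloro carries the lower number. Compound 1 now stands lower than both of its single-change neighbours, with both of the places varied so far giving a higher number on change. No measurement on hand bears on why trifluoromethyl gives the higher number here.

For the compounds shown here, with only two groups at this position, it remains open whether fluoro, methoxy or a plain hydrogen would give a number lower than that of compound 1. Also open, going by these compounds, is whether the same change would give a step of similar size on the pyridin-3-yl thiourea of compound 2.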